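Chloro Added to the Benzoyl Ring of a Second Analogue

The source may report more compounds than this note shows. Statements on the series, on what has been measured and on what is new or still open speak of the compounds shown alone.

Measured compounds:
Compound 1, `O=C(Nc1ccccc1C(F)(F)F)C1CCc2ccccc2N1C(=O)c1cccc(Cl)c1`: 729 nM
Compound 2, `O=C(Nc1ccccc1C(F)(F)F)C1CCc2ccccc2N1C(=O)c1ccccc1`: 5560 nM
Compound 3, `O=C(Nc1cc(C(F)(F)F)cc(C(F)(F)F)c1)C1CCc2ccccc2N1C(=O)c1ccccc1`: 3500 nM

In a functional assay on PC-3 cells (Homo sapiens) for cytotoxicity, read by sulforhodamine B assay, with a stated time of 72 h (on this read-out higher numbers stand for weaker inhibition of growth and lower numbers for stronger inhibition of growth), compound 2 gives 5560 nM, and compound 1 gives 729 nM. The two differ by one change, (chloro in place of hydrogen on an aromatic carbon), and that change made the step of a 7.6-fold lower number from compound 2 to compound 1 (0.88 log units; beyond the scatter). Compound 3 gives 3500 nM in this assay; the difference between the core of compound 3 and the core of compound 2 is not broken down here, and their two values lie within the usual scatter of each other.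

Compound 4, `O=C(Nc1cc(C(F)(F)F)cc(C(F)(F)F)c1)C1CCc2ccccc2N1C(=O)c1cccc(Cl)c1`, has not yet been measured. It differs from compound 3 by chloro in place of hydrogen on an aromatic carbon, the same change that leads from compound 2 to compound 1, occurring twice among these compounds. Because the earlier step was a 7.6-fold lower number from compound 2 to compound 1 (0.88 log units; beyond the scatter), a step of similar direction is expected for compound 4, though somewhat smaller, since one prior example is thin ground. The expected step is a 5.4-fold lower number from compound 3 to compound 4 (0.73 log units; beyond the scatter). Compound 4 is therefore estimated at 650 nM in this assay, with a likely range from 220 nM to 2200 nM.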

Compound 4, concentration for 50% growth inhibition: 1050 nM
Compound 4: the middle estimate sits 1.6-fold (0.21 log units) below what was measured, within the range that was stated.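

Chloro in place of hydrogen on the benzoyl ring again strengthens growth inhibition on a second core, giving in this assay a 3.3-fold lower number from compound 3 to compound 4 (0.52 log units; beyond the scatter). The two steps point the same way, and the gap between their sizes is no larger than repeated measurements could produce: the same change on two cores in this assay, a 7.6-fold lower number (0.88 log units; beyond the scatter) from compound 2 to compound 1 and a 3.3-fold lower number (0.52 log units; beyond the scatter) from compound 3 to compound 4, 2.3-fold (0.36 log units) apart, within the scatter of two such steps. For the compounds shown here, this shows that the gain carried over between these two cores, but it rests on only one pair of compounds per core, so it does not show that the change would help on any other core, and it says nothing about why the number falls.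

The compounds shown leave open whether a different group in the same place, such as a fluoro, a methoxy or an amine, would match chloro on this ring. They also leave open whether the chloro step would hold if the trifluoromethyl groups of the shared amide part gave way to a nitrile or a carboxylic acid.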